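A few compounds are considered here, and "the series" means these few. Any claim that something is new, unique, unknown or untested is made for them only; others in the source may bear on it.

Measured so far in a functional assay on LOX IMVI cells (Homo sapiens) for inhibition, read by sulforhodamine B assay, with a stated time of 48 h; on this read-out lower numbers stand for stronger inhibition of growth and higher numbers for weaker inhibition of growth:
compound 1 `COc1cc(-c2nn(-c3cccc(NC(=O)Nc4ccc(Cl)c(Cl)c4)c3)cc2-c2ccncc2)ccc1Cl`, 2620 nM
compound 2 `O=C(Nc1cccc(-n2cc(-c3ccncc3)c(-c3ccc(Cl)c(O)c3)n2)c1)Nc1ccc(Cl)c(Cl)c1`, 3570 nM
compound 3 `O=C(Nc1cccc(-n2cc(-c3ccncc3)c(-c3ccc(Cl)c(O)c3)n2)c1)Nc1cc(C(F)(F)F)cc(C(F)(F)F)c1`, 1400 nM

Compound 1 stands second highest of the three numbers; compound 2 sits nearest, at a 1.4-fold higher number from compound 1 to compound 2 (0.13 log units; within the scatter), and compound 3 furthest, a gap that also lies within the scatter. Compound 4 `COc1cc(-c2nn(-c3cccc(NC(=O)c4ccccc4)c3)cc2-c2ccncc2)ccc1Cl` differs from compound 1 by phenyl in place of (3,4-dichlorophenyl)amino on a carbonyl carbon. Within the data shown here, no measured step touches this part of the molecule: the only recorded step, from compound 1 to compound 2, concerns the oxygen on the aromatic ring and is within the scatter. Compounds 2 and 3 carry different aryl groups on the urea, but their values show only a small gap. Among the measured compounds shown here, with no direct precedent, a moderate rise in this assay, beyond the scatter, is expected for compound 4, at a 2.5-fold higher number from compound 1 to compound 4 (0.39 log units; beyond the scatter); the estimate for compound 4 is 6500 nM, within 2200 nM to 20000 nM.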

Compound 4, concentration for total growth inhibition: > 100000 nM
Compound 4: only a limit was reported; the forecaster's own chance of this, stated with the estimate: 15%; middle value at least 15-fold (1.18 log units) from the limit.
By their numbers in this assay, from the lowest: compounds 3, 1 and 2 (each within the scatter of the next, the first and the last beyond it). At a limit, above all of these: compound 4.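

In this assay, among these compounds, the group on this carbonyl carbon gives the first large change (an at least 38-fold higher number from compound 1 to compound 4 (1.58 log units; beyond the scatter)), while the one earlier step stays within the scatter. Compound 4 gives only a limit of the assay, not a number: the limit of > 100000 nM in this assay, at which 1 of the 4 values shown sits. Among the steps shown, this position therefore counts for far more than the hydrogen-for-methyl change on the aromatic oxygen.

On these data alone, the step removes the amino nitrogen and both chlorines at once, so it remains open which of these carries the loss. Phenylamino on the same carbonyl carbon would separate the two.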